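The source may report more compounds than this note shows. Statements on the series, on what has been measured and on what is new or still open speak of the compounds shown alone.

Three compounds have been measured in an assay on isolated protein for inhibition of Amine oxidase [flavin-containing] B (Rattus norvegicus); a lower number here means a stronger inhibitor, a higher number a weaker inhibitor:

Compound 1 `CC#CCN(C)Cc1cc2cc(O)ccc2n1C` gives 8800 nM.
Compound 2 `C#CCN(C)Cc1cc2cc(O)ccc2n1C` gives 820 nM.
Compound 3 `C#CCN(C)Cc1cc2ccccc2n1C` gives 3 nM.

Compound 4 `CC#CCN(C)Cc1cc2ccccc2n1C` has not yet been measured. It is related to compound 3 by methyl in place of hydrogen on a triple-bonded carbon. The same change occurs once among the measured compounds, from compound 2 to compound 1, where it reads (methyl in place of hydrogen on a triple-bonded carbon); the place is the same in both cases, so this is the same change. There it produced an 11-fold higher number from compound 2 to compound 1 (1.03 log units; beyond the scatter), a large step beyond the scatter.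

Compound 4 shares the core of compound 3. The core of compound 3 differs from the core of compound 2 by hydrogen in place of hydroxy on an aromatic carbon, and that step gave a 270-fold lower number from compound 2 to compound 3 (2.44 log units; beyond the scatter), also far beyond the scatter. Compound 3 therefore stands with the lowest number of the three measured compounds, with both others beyond the scatter from it.

Among the compounds with values here, the expectation for compound 4 rests on the single earlier instance of the change, which gave an 11-fold higher number from compound 2 to compound 1 (1.03 log units; beyond the scatter). Compound 4 is therefore expected to show a step of an 11-fold higher number from compound 3 to compound 4 (1.04 log units; beyond the scatter) in this assay. Whether the step keeps its size on a core that carries hydrogen rather than hydroxy cannot be told from the data shown, so the range is kept wide. Compound 4 is expected to give about 33 nM in this assay, between 10 nM and 110 nM.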

Compound 4, inhibition constant: 30 nM
Compound 4: middle estimate off by 1.1-fold (0.04 log units), on the high side; the range from low to high includes it.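

In this assay, methyl in place of hydrogen on the triple-bonded carbon gave a 10-fold higher number from compound 3 to compound 4 (1.00 log units; beyond the scatter), and this step on the core that carries hydrogen matches the one seen on the core that carries hydroxy: the same change on two cores in this assay, an 11-fold higher number (1.03 log units; beyond the scatter) from compound 2 to compound 1 and a 10-fold higher number (1.00 log units; beyond the scatter) from compound 3 to compound 4, 1.1-fold (0.03 log units) apart, within the scatter of two such steps. Read the other way round, hydrogen in place of hydroxy on an aromatic carbon gave a 290-fold lower number from compound 1 to compound 4 (2.47 log units; beyond the scatter), and this step too held whichever group stood on the triple-bonded carbon: the same change on two cores in this assay, a 270-fold lower number (2.44 log units; beyond the scatter) from compound 2 to compound 3 and a 290-fold lower number (2.47 log units; beyond the scatter) from compound 1 to compound 4, 1.1-fold (0.03 log units) apart, within the scatter of two such steps. Across these four compounds, then, each change kept its size when the other was present, so the two steps could be carried from one core to the other; this rests on only two cores and one assay, however, and it shows neither that the same would hold on other cores nor why either change has the size it has.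

On these data alone, it remains open how far the step runs along the triple-bonded carbon if an ethyl group or a longer chain takes the place of the methyl. As far as these compounds go, it is equally open whether a methoxy group or an amine on the aromatic carbon would fall in line with hydroxy or with hydrogen, and whether such groups would leave the methyl step unchanged.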